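Varying the amide group on a shared core

The source may report more compounds than this note shows. Statements on the series, on what has been measured and on what is new or still open speak of the compounds shown alone.

Three compounds share one core and differ only in the group attached to the carbonyl carbon. Compound 1 `COCCNC(=O)C1CCN(c2ccc(Cl)c(C(F)(F)F)c2)C1` gives 3500 nM in an assay on cells for inhibition of Palmitoleoyl-protein carboxylesterase NOTUM variant C330S (Homo sapiens), read by fluorescence, with a stated time of 40 min; a lower number here means a stronger inhibitor, a higher number a weaker inhibitor. Compound 2 `O=C(C1CCN(c2ccc(Cl)c(C(F)(F)F)c2)C1)N1CCOCC1` gives 9700 nM in this assay, and compound 3 `O=C(C1CCN(c2ccc(Cl)c(C(F)(F)F)c2)C1)N1CC2COCC2C1` gives 3100 nM. Compound 3 therefore has the lowest number of the three, but its gap to compound 1, a 1.1-fold lower number from compound 1 to compound 3 (0.05 log units; within the scatter), is within the scatter, while its gap to compound 2, a 3.1-fold lower number from compound 2 to compound 3 (0.50 log units; beyond the scatter), is beyond it.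

Compound 4 `CN1CN(C(=O)C2CCN(c3ccc(Cl)c(C(F)(F)F)c3)C2)CC1=O` has not yet been measured. It differs from compound 3 by a group of 7 heavy atoms (4 carbon, 2 nitrogen, 1 oxygen; one five-membered non-aromatic ring with 2 hetero atoms) in place of a group of 8 heavy atoms (6 carbon, 1 nitrogen, 1 oxygen; 2 five-membered non-aromatic rings with 1 hetero atom each), on a carbonyl carbon. The measured steps that bear on this are the other exchanges at the same carbonyl carbon: a 2.8-fold higher number from compound 1 to compound 2 (0.44 log units; beyond the scatter) and a 3.1-fold lower number from compound 2 to compound 3 (0.50 log units; beyond the scatter), both modest, while a 1.1-fold lower number from compound 1 to compound 3 (0.05 log units; within the scatter) shows no change beyond the scatter. Exchanges at this position have so far moved the number only modestly. The incoming group in compound 4 is a single small ring with two hetero atoms, closer in kind to the six-membered ring of compound 2 than to the two fused rings of compound 3, so a modest rise is expected, a 1.9-fold higher number from compound 3 to compound 4 (0.29 log units; within the scatter). Compound 4 is thus estimated at 6000 nM in this assay, with a range from 2500 nM to 15000 nM.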

Compound 4, half-maximal inhibitory concentration: 1400 nM
Compound 4: the middle estimate sits 4.3-fold (0.63 log units) above what was measured; the whole stated range lies above it.
By their numbers in this assay, from the lowest: compound 4; then compounds 3 and 1 (each within the scatter of the next); then compound 2.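

In this assay, the group in compound 4, with one five-membered non-aromatic ring holding 2 hetero atoms and a double bond outside aromatic rings, gives a lower number than every earlier group, with a 2.2-fold lower number from compound 3 to compound 4 (0.35 log units; beyond the scatter) and a 2.5-fold lower number from compound 1 to compound 4 (0.40 log units; beyond the scatter) and a 6.9-fold lower number from compound 2 to compound 4 (0.84 log units; beyond the scatter) all beyond the scatter. The last of these is the largest step yet seen at this carbonyl carbon, so the position responds more strongly to the choice of group than the first three compounds suggested. Size does not order the results either, since the group in compound 4 is smaller than that in compound 3 and gives a lower number, while the group in compound 2, smaller still, gives the highest number and the ring-free group in compound 1, the smallest of all, gives a lower number than compound 2; nothing available here bears on the reason for this result.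

Going by these compounds, it remains open whether the lower number of compound 4 depends on its double bond outside aromatic rings or on the five-membered ring itself. On these data alone, how an amine or a carboxylic acid on the incoming ring, or a longer chain on the carbonyl carbon, would read in this assay also remains open.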